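This account rests on a few compounds, and the source may have more. Where it says the series, first, only, none or still open, it means among the compounds named here.

Measured in an ADME assay on Huh-7 cells (Homo sapiens) for cytotoxicity; on this read-out lower numbers stand for higher toxicity in this test and higher numbers for lower toxicity in this test:
- Compound 1 `NC(=S)Nc1cccc(OCCCCCCCCNC(=S)Nc2ccccc2)c1`: > 50000 nM, which is a limit of this assay rather than a number.
- Compound 2 `NC(=S)Nc1cccc(OCCCCCCCCNC(=S)Nc2ccc(Cl)cc2)c1`: 18000 nM.
- Compound 3 `CC(C)(C)c1ccc(NC(=S)NCCCCCCCCOc2cccc(NC(N)=S)c2)cc1`: 17000 nM.

Compound 3 gives the lowest of the two numbers; compound 2 lies within the scatter of it, so the two are not ordered. Compound 4 `NC(=S)Nc1cccc(OCCCCCCCCNC(=S)Nc2ccc(C3CCCCC3)cc2)c1` carries cyclohexyl in place of tert-butyl on an aromatic carbon. For the measured compounds named here, no measured step involves a cyclohexyl group. Going by the values given here, the steps that bear on this change are an at least 2.7-fold lower number from compound 1 to compound 2 (0.44 log units; beyond the scatter) and an at least 2.9-fold lower number from compound 1 to compound 3 (0.46 log units; beyond the scatter), both beyond the scatter, and a 1.1-fold lower number from compound 2 to compound 3 (0.02 log units; within the scatter), within it: exchanging one group for another at this position changed little. A step of a 1.1-fold lower number from compound 3 to compound 4 (0.05 log units; within the scatter) is therefore expected, not beyond the scatter. Compound 4 is estimated at 15000 nM, between 7000 nM and 35000 nM.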

Compound 4, half-maximal cytotoxic concentration: > 50000 nM
Compound 4: no number, only a limit; the forecaster's own chance of this, stated with the estimate: 10%; at least 3.3-fold (0.52 log units) between middle value and limit.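

In this assay, the earlier exchange of chloro for tert-butyl suggested that this position tolerates a change of group, but cyclohexyl gives an at least 2.9-fold higher number from compound 3 to compound 4 (0.46 log units; beyond the scatter) and an at least 2.7-fold higher number from compound 2 to compound 4 (0.44 log units; beyond the scatter). Compound 4 gives > 50000 nM, a limit and not a number. The step from compound 1 to compound 4 cannot be read because both values are limits: the limit of > 50000 nM in this assay, at which 2 of the 4 values shown sit.

On these data alone, it remains open whether a phenyl, a methoxy or an amine at this position would group with chloro and tert-butyl or with cyclohexyl. As far as these compounds go, how far compound 1 and compound 4 actually differ also stays open.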